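The compounds below may be only part of what the source reports. "The series", "measured", "known", "first", "only" and "open" are said of these compounds alone.

Of the compounds shown here, two have so far been measured in a functional assay on the whole organism for inhibition, with Rattus norvegicus as the target, at a dose of 1 mg/kg by the intravenous route; on this read-out higher numbers stand for a stronger effect at the one dose given and lower numbers for a weaker effect. Compound 1, `CCCCc1n[nH]c(C(=O)OCC)c1Cc1ccc(-c2ccccc2-c2nn[nH]n2)cc1`, gives 80%. Compound 2, `CCCc1nn(-c2c(Cl)cccc2Cl)c(C(=O)O)c1Cc1ccc(-c2ccccc2-c2nn[nH]n2)cc1`, gives 100%. On these two numbers compound 2 stands highest, and its gap to compound 1 lies beyond the usual scatter of repeated measurements of this kind.

Compound 3, `CCCc1nn(-c2ccccc2C(F)(F)F)c(C(=O)O)c1Cc1ccc(-c2ccccc2-c2nn[nH]n2)cc1`, has not yet been measured in this assay. It differs from compound 2 in one place: 2-(trifluoromethyl)phenyl in place of 2,6-dichlorophenyl on an aromatic nitrogen. Among the measured compounds shown here, no measured pair of compounds differs only in this way, so there is no step of the same kind to lean on, and the expectation rests on compound 2 alone. Because compound 2 gives 100%, which is the full read-out of this assay, there is room only to fall, and the carboxy group, the propyl group and the rest of the shared core are unchanged in compound 3. The step of a number 10 percentage points lower from compound 2 to compound 3 (within the scatter) is estimated to be small and downward, at most a little beyond the scatter. Compound 3 is therefore expected to give 90%, with a likely range from 70% to 100%.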

Compound 3, a percentage reported as inhibition, in the whole organism at one dose (the size of the read-out at that dose, not a potency): 100%
Compound 3: the middle estimate sits 10 percentage points below what was measured, within the range that was stated.
By their numbers in this assay, from the lowest: compound 1; then compounds 2 and 3 (each within the scatter of the next).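

Measured in this assay the change from 2,6-dichlorophenyl to 2-(trifluoromethyl)phenyl on the aromatic nitrogen gives no change at the digits printed from compound 2 to compound 3 (within the scatter) and so shows that this position keeps the full read-out with a second substituted phenyl ring, while the carboxy group, the propyl group and the rest of the shared core stay the same. The two chlorine atoms of compound 2 are therefore not required for the effect at this dose, since a ring with a single trifluoromethyl group and no chlorine serves as well. Nothing measured here accounts for this result in terms of any property of the two groups.

Both compounds sit at the top of the read-out, so this single dose cannot tell whether either is stronger, and only a lower dose could try to separate them. Also open, as far as these compounds go, is whether the ring on this nitrogen needs a substituent at all, and how far the position can be pushed before the effect falls: a plain phenyl, a simple methyl in place of the ring, or a phenyl carrying an amine or a carboxylic acid would each test that.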